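The source may report more compounds than this note shows. Statements on the series, on what has been measured and on what is new or still open speak of the compounds shown alone.

Values in a functional assay on MCF7 cells (Homo sapiens) for antiproliferative activity, read by MTT assay, with a stated time of 48 h; on this read-out lower numbers stand for stronger inhibition and higher numbers for weaker inhibition:
- Compound 1 `CC(=O)N1N=C(c2ccc3ccccc3c2)OC1c1ccccc1F`: 3.44 ug/mL
- Compound 2 `CC(=O)N1N=C(c2ccc3ccccc3c2)OC1c1ccc([N+](=O)[O-])cc1`: 7.59 ug/mL
- Compound 3 `CC(=O)N1N=C(c2ccc3ccccc3c2)OC1c1ccccc1O`: 2.12 ug/mL

Compound 3 sits at the low end of these numbers, level with compound 1 within the scatter and apart from compound 2. The next change gives compound 4 `CC(=O)N1N=C(c2ccc3ccccc3c2)OC1c1ccc(C)cc1`: 4-methylphenyl in place of 2-hydroxyphenyl on a saturated ring carbon.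

Going by the values given here, two measured steps bear on it: a 1.6-fold lower number from compound 1 to compound 3 (0.21 log units; within the scatter) and a 3.6-fold lower number from compound 2 to compound 3 (0.55 log units; beyond the scatter). Neither tests 4-methylphenyl, so the data give only a rough guide. A modest step to a higher number is expected in this assay, with compound 4 landing between compound 3 and compound 2.

The expected change is a 2.1-fold higher number from compound 3 to compound 4 (0.33 log units; beyond the scatter).

For compound 4 the estimated value is 4.5 ug/mL, with an expected range of 2.2 ug/mL to 8.5 ug/mL.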

Compound 4, half-maximal inhibitory concentration: 2.9 ug/mL
Beside the measured number, compound 4's estimate is 1.6-fold (0.19 log units) above it; the range from low to high includes it.
By their numbers in this assay, from the lowest: compounds 3, 4 and 1 (each within the scatter of the next); then compound 2.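

In this assay, the 4-methylphenyl group keeps compound 4 level with the 2-hydroxyphenyl compound (a 1.4-fold higher number from compound 3 to compound 4 (0.14 log units; within the scatter)) and the 2-fluorophenyl compound (a 1.2-fold lower number from compound 1 to compound 4 (0.07 log units; within the scatter)), so a hydrogen-bond donor and acceptor on this aryl group are not needed to stay in that range. The direct swap of nitro for methyl on an aromatic carbon gives a 2.6-fold lower number from compound 2 to compound 4 (0.42 log units; beyond the scatter), leaving compound 2 as the only one apart from the rest.

Nothing shown explains that gap. From the compounds shown here alone, an amine or a carboxylic acid in place of the methyl of compound 4 remains open.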